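The compounds below may be only part of what the source reports. "The series", "measured", "known", "first", "only" and "open" are said of these compounds alone.

Working notes on the series.

Two members carry a measurement in a functional assay, read by Griess assay, with a stated time of 150 min, tested at 75 ug/mL; on this read-out lower numbers stand for a weaker effect and higher numbers for a stronger effect at the one concentration tested. Compound 1 `COc1ccc(-c2nn(-c3ccccc3)c(-c3ccc(C)cc3)c2S(=O)(=O)CC2=NCCS2)cc1` is recorded in this assay as "not active" (no number reported), with no number attached to it. Compound 2 `Cc1ccc(C2CNN=C2S(=O)(=O)CC2=NCCS2)cc1` gives 48.6% in this assay, and on the numbers shown compound 2 therefore stands alone: it is the only compound with a value, and compound 1 contributes no figure that could be set against it. Within the data shown here, no step between measured compounds is available.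

Compound 3 `O=S(=O)(CC1=NCCS1)C1=NNCC1c1ccccc1` is the next member to be measured in this assay. Compound 3 differs from compound 2 by hydrogen in place of methyl on an aromatic carbon, the 4-methylphenyl of compound 2 becoming phenyl in compound 3, with the rest of the shared core kept.

With nothing in the measured set to fix the size of this change, a step of a number 6.6 percentage points lower from compound 2 to compound 3 (within the scatter) is expected, that is, no movement beyond the usual scatter, leaning slightly downward. Compound 3 is accordingly estimated at 42%, with a range from 24% to 58%.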

Compound 3, a percentage reported as activity, at one concentration (the size of the read-out at that concentration, not a potency): "not active" (no number reported)
Compound 3 has no reported number here; no gap can be computed for the estimate.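

In this assay, among these compounds, compound 3 stands as "not active" (no number reported), so no step from compound 2 to compound 3 can be read. Nothing available explains this result. The compounds shown leave open how large an effect the change from 4-methylphenyl to phenyl has on this read-out.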